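The compounds below may be only part of what the source reports. "The series", "measured", "known", "first", "only" and "open" are said of these compounds alone.

Of the compounds shown here, three built on one shared core have been measured. Compound 1 `CCCCn1c(-c2ccccc2)c(C)[nH]c1=O` carries a butyl group on the ring nitrogen. In a functional assay on brain (Rattus norvegicus, strain Wistar) for inhibition (a lower number here means a stronger inhibitor, a higher number a weaker inhibitor), compound 1 reaches only a limit, > 100000 nM, that is, (the limit of > 100000 nM in this assay, at which 1 of the 3 values shown sits). Compound 2 `Cc1[nH]c(=O)n(C2CCCCC2)c1-c1ccccc1` gives 47600 nM in this assay, and the change is an at least 2.1-fold lower number from compound 1 to compound 2 (0.32 log units; beyond the scatter). Compound 3 `Cc1ccc(-c2c(C)[nH]c(=O)n2C)cc1` gives 85300 nM in this assay; its number lies within the usual scatter of the number of compound 2, so the two cannot be told apart, and compound 1 offers no number at all.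

Compound 4 `CCCCCCOc1ccc(-c2c(C)[nH]c(=O)n2C)cc1` differs from compound 3 by hexyloxy in place of methyl on an aromatic carbon. For the measured compounds named here, no measured step touches this position: the only step known, the one from compound 1 to compound 2, changes the group on the nitrogen, not on the carbon ring. There is therefore no basis for a direction, and the expected step is one within the scatter, a 1.7-fold lower number from compound 3 to compound 4 (0.23 log units; within the scatter). Compound 4 is estimated at 50000 nM in this assay, within 10000 nM to 200000 nM, with a real chance that only a limit is reported.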

Compound 4, half-maximal inhibitory concentration: 7300 nM
Estimate against measurement, compound 4: 6.8-fold (0.84 log units) above, and the stated range ends above it.
By their numbers in this assay, from the lowest: compound 4; then compounds 2 and 3 (each within the scatter of the next). At a limit, above all of these: compound 1.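

Placing hexyloxy in place of methyl on the aromatic carbon gives a 12-fold lower number from compound 3 to compound 4 (1.07 log units; beyond the scatter) in this assay. For the compounds shown here, until now, the only step that could be read concerned the group on the ring nitrogen, so this is the first sign that the number also responds to a change on the carbon ring. Nothing measured here explains why this change has such an effect.

The compounds shown leave open whether the step comes from the oxygen, from the length of the chain, or from both, since hexyloxy differs from methyl in both respects. A methoxy group, a hexyl chain without the oxygen, and a longer octyloxy chain at the same place would help to separate these possibilities and show whether the trend continues.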